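A few compounds are considered here, and "the series" means these few. Any claim that something is new, unique, unknown or untested is made for them only; others in the source may bear on it.

Three compounds sharing one core, and differing in a single group, have been tested in a functional assay on K562 cells (Homo sapiens) for cytotoxicity, read by fluorescence, with a stated time of 72 h; on this read-out lower numbers stand for stronger inhibition and higher numbers for weaker inhibition. Compound 1 `CSc1nc(NCc2ccc(-c3ccccn3)cc2)c2[nH]nc(C(C)C)c2n1` gives 778 nM with methylsulfanyl at that place. Compound 2 `CC(C)c1n[nH]c2c(NCc3ccc(-c4ccccn4)cc3)nc(N3CCCCC3CCO)nc12` gives 165 nM with 2-(2-hydroxyethyl)piperidin-1-yl there. Compound 3 `CC(C)c1n[nH]c2c(NCc3ccc(-c4ccccn4)cc3)nc(N3CCNCC3)nc12` gives 17 nM with piperazin-1-yl, the lowest of the three numbers and so the strongest inhibition in this small set.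

The next compound is compound 4 `COc1ccc(CNc2nc(NCc3ccc(-c4ccccn4)cc3)c3[nH]nc(C(C)C)c3n2)cc1`, which carries (4-methoxybenzyl)amino in place of piperazin-1-yl on an aromatic carbon between two ring nitrogen atoms. The count of what changes is (4-methoxybenzyl)amino in place of piperazin-1-yl on an aromatic carbon and nothing else differs.

Among the compounds with values here, no tested compound carries the entering group, so the evidence is indirect. The group at this place clearly matters, as shown by a 4.7-fold lower number from compound 1 to compound 2 (0.67 log units; beyond the scatter) and by the two steps that bring in piperazin-1-yl, a 46-fold lower number from compound 1 to compound 3 (1.66 log units; beyond the scatter) and a 9.7-fold lower number from compound 2 to compound 3 (0.99 log units; beyond the scatter) in this assay. Compound 4 gives up that piperazin-1-yl, and neither other group came close to the value of compound 3, so a move to a higher number is expected, of modest to large size. The estimated change is a 15-fold higher number from compound 3 to compound 4 (1.17 log units; beyond the scatter) in this assay, a step beyond the scatter. Compound 4 is expected at about 250 nM, within an estimated range from 60 nM to 1000 nM.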

Compound 4, half-maximal inhibitory concentration: 3950 nM
Compound 4: middle estimate off by 16-fold (1.20 log units), on the low side; the whole stated range lies below it.
By their numbers in this assay, from the lowest: compound 3; then compound 2; then compound 1; then compound 4.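

In this assay, the group on the aromatic carbon between two ring nitrogen atoms turns out to control a much wider range than the first three compounds showed, with (4-methoxybenzyl)amino at the weak end (a 230-fold higher number from compound 3 to compound 4 (2.37 log units; beyond the scatter)) and (a 24-fold higher number from compound 2 to compound 4 (1.38 log units; beyond the scatter)). Until now, every replacement of methylsulfanyl had lowered the number, but this one raises it (a 5.1-fold higher number from compound 1 to compound 4 (0.71 log units; beyond the scatter)), so attachment through a nitrogen atom at this place does not by itself bring stronger inhibition. Piperazin-1-yl and (4-methoxybenzyl)amino have the same counts of hydrogen-bond donors and acceptors and no net charge, so those counts do not separate them, and no measurement shown here explains the gap.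

Going by these compounds, the step away from piperazin-1-yl changes several features at once, so it remains open whether the methoxy group, the benzene ring or the open-chain amino link accounts for the loss, which a plain benzylamino group would help to separate. On these data alone, it is also open how much of the strength of compound 3 (17 nM) depends on the second ring nitrogen, which a morpholine ring, with oxygen in its place, or a 4-methylpiperazine ring would test.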